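This account rests on a few compounds, and the source may have more. Where it says the series, first, only, none or still open, it means among the compounds named here.

Compound 1 `NS(=O)(=O)c1ccc2nc(N3N=C(c4ccc(Br)cc4)CC3c3ccc(F)cc3)sc2c1`: 14%
Compound 2 `Cc1ccc(C2CC(c3ccc(Cl)cc3)=NN2c2nc3ccc(S(N)(=O)=O)cc3s2)cc1`: 14%

Both were run in a functional assay on the whole organism (strain Wistar) for inhibition, with Rattus norvegicus as the target, read by paw edema, with stated times of 1 h and 5 h, at a dose of 20 mg/kg by the oral route; a higher number here means more inhibition at the dose given (going by the name of the read-out), a lower number less inhibition. In this assay compound 1 gives 14% and compound 2 gives 14%, so the two stand within the scatter of each other and nothing separates them. Compound 3 `CN(C)c1ccc(C2CC(c3ccc(Cl)cc3)=NN2c2nc3ccc(S(N)(=O)=O)cc3s2)cc1` is the next member, not yet measured. It differs from compound 2 in one place: dimethylamino in place of methyl on an aromatic carbon. Among the compounds with values here, with no measured step in the set against which this change could be gauged, no movement beyond the scatter is expected. Compound 3 is expected to give about 16% in this assay, between 4% and 32%. The expected step from compound 2 to compound 3 is a number 2 percentage points higher from compound 2 to compound 3 (within the scatter), in effect flat.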

Compound 3, a percentage reported as inhibition, in the whole organism at one dose (the size of the read-out at that dose, not a potency): 14%
Compound 3: the middle estimate sits 2 percentage points above what was measured; low and high end bracket the measured number.
By their numbers in this assay, from the lowest: compounds 1, 2 and 3 (each within the scatter of the next).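

In this assay the read-out shows no change at the digits printed from compound 2 to compound 3 (within the scatter) when dimethylamino replaces methyl on an aromatic carbon, para to a large group. Within the data shown here, this is the first step measured at this position, and the 4-methylphenyl and 4-(dimethylamino)phenyl members cannot be told apart here, although the entering group adds a nitrogen and a hydrogen-bond acceptor. No evidence at hand speaks to the origin of this result. Open, on these data alone, is whether a carboxylic acid, a primary amine or a longer chain such as butyl at this place would give a step beyond the scatter.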